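One Flipped Ring Stereocentre, Clearance Expected Unchanged

A few compounds are considered here, and "the series" means these few. Any claim that something is new, unique, unknown or untested is made for them only; others in the source may bear on it.

compound 1, `CCCO[C@@H]1O[C@H](CNC(=O)c2ccc(S(N)(=O)=O)cc2)[C@@H](O)[C@H](O)[C@@H]1O`: 1.42 mL/min/kg
compound 2, `CCO[C@@H]1O[C@H](CNC(=O)c2ccc(S(N)(=O)=O)cc2)[C@@H](O)[C@H](O)[C@H]1N`: 1.56 mL/min/kg

In an ADME assay on microsomes from liver (Mus musculus) for metabolic stability (a lower number here means slower removal, a higher number faster removal of the compound), compound 1 gives 1.42 mL/min/kg and compound 2 gives 1.56 mL/min/kg. Compound 1 stands at one end of this pair, with compound 2 within the scatter of it, so the two numbers cannot be told apart. Within the data shown here, no pair of measured compounds differs in only one place, so no measured step is available. Compound 3, `CCCO[C@@H]1O[C@H](CNC(=O)c2ccc(S(N)(=O)=O)cc2)[C@@H](O)[C@H](O)[C@H]1O`, differs from compound 1 as follows: the two compounds have the same atoms and bonds and differ only in configuration as drawn: 1 of 5 stereo elements differ; a stereocentre at a saturated ring carbon is drawn S in compound 1 and R in compound 3. A change of configuration alone is expected to give no step beyond the scatter, so the estimated step of a 1.1-fold higher number from compound 1 to compound 3 (0.02 log units; within the scatter) is small. Compound 3 is therefore expected to give 1.5 mL/min/kg, in the range 0.8 mL/min/kg to 3 mL/min/kg.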

Compound 3, clearance: 1.53 mL/min/kg
The estimate for compound 3 lay 1.0-fold (0.01 log units) below the measured number, and the stated range covers the measured number.
By their numbers in this assay, from the lowest: compounds 1, 3 and 2 (each within the scatter of the next).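

Among these compounds, this is the first step that changes just one thing, so it can be read directly. In this assay, redrawing this saturated ring carbon from S to R gives a 1.1-fold higher number from compound 1 to compound 3 (0.03 log units; within the scatter), so the number does not tell the two configurations apart. Any reading of this step rests on a single structural difference: the fact that compounds 1 and 3 differ only in the configuration as drawn

On these data alone, the other stereo elements stay the same in this pair, so their configurations remain untested here. Also open, as far as these compounds go, is whether a new group at this ring carbon, such as a carboxylic acid, would give a step beyond the scatter.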